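The compounds below may be only part of what the source reports. "The series", "measured", "known", "first", "only" and "open" are said of these compounds alone.

Measured in a functional assay on PANC-1 cells (Homo sapiens) for cytotoxicity, read by WST assay, with a stated time of 24 h; a lower number here means a stronger inhibitor, a higher number a weaker inhibitor:

- Compound 1 `O=C(/C=C/CCCCCCc1ccccc1)NCc1ccccc1` gives > 100000 nM (a limit, not a number)
- Compound 2 `O=C(CCCCCCCc1ccccc1)N1CCCCC1` gives > 100000 nM (a limit, not a number)
- Compound 3 `O=C(CCCCCCCCc1ccc(C(F)(F)F)cc1)N1CCCCC1` gives 54000 nM (a true number)

For the measured compounds named here, compound 3 holds the only real number in this small set, and at 54000 nM it has no measured neighbour to compare with. The other two results are limits: the limit of > 100000 nM in this assay, at which 2 of the 3 values shown sit, tells how little they reveal.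

The next compound, compound 4 `O=C(CCCCCCCCc1ccc(F)cc1)N1CCCCC1`, changes one group of compound 3. The change is fluoro in place of trifluoromethyl on an aromatic carbon and it amounts to fluoro in place of trifluoromethyl on an aromatic carbon, para to a large group. Going by the values given here, no pair of measured compounds differs in one place only, so nothing here sizes this swap directly. In this assay no step beyond the usual scatter is therefore expected, and the assay could also return only a limit. The estimated change is a 1.5-fold higher number from compound 3 to compound 4 (0.17 log units; within the scatter) and it leans slightly toward the weaker side. Compound 4 is expected at 80000 nM as a best estimate. The expected range for compound 4 runs from 35000 nM to 150000 nM in this estimate.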

Compound 4, half-maximal inhibitory concentration: 99800 nM
The estimate for compound 4 lay 1.2-fold (0.10 log units) below the measured number, and the stated range covers the measured number.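

Compound 3 and compound 4 are the first pair shown that differ in one place only, so this position can now be sized directly. In this assay, replacing trifluoromethyl (4 heavy atoms) with fluoro (1 heavy atom) on an aromatic carbon, para to a large group, gives a 1.8-fold higher number from compound 3 to compound 4 (0.27 log units; within the scatter), so the two compounds cannot be told apart. This single swap therefore shows no sign that the assay distinguishes these two groups at this position, though the read-out offers limited room, as limits make up much of the set: the limit of > 100000 nM in this assay, at which 2 of the 4 values shown sit.

On these data alone, whether a carboxylic acid, an amine or a methoxy group at this position would give a step beyond the scatter remains open. So does the effect of a plain hydrogen there on the same chain and core.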